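Chloro for hydrogen across two cores: paw edema notes

The compounds below may be only part of what the source reports. "The series", "measured", "known", "first", "only" and "open" are said of these compounds alone.

Compound 1 `O=C(N/N=C/c1ccccc1)c1cccnc1Nc1cccc(C(F)(F)F)c1` is measured in a functional assay on the whole organism (strain Wistar) for inhibition, with Rattus norvegicus as the target, read by paw edema, with a stated time of 2 h, at a dose of 10 mg/kg by the intraperitoneal route (on this read-out higher numbers stand for more inhibition at the one dose given (going by the name of the read-out) and lower numbers for less inhibition), and gives 36.8%. Compound 2 `O=C(N/N=C/c1cccc(Cl)c1)c1cccnc1Nc1cccc(C(F)(F)F)c1` carries the change (chloro in place of hydrogen on an aromatic carbon); in this assay compound 2 gives 63.5%, and the step is a number 26.7 percentage points higher from compound 1 to compound 2 (beyond the scatter). Compound 3 `CNc1ncccc1C(=O)N/N=C/c1ccccc1` rests on another core; the difference between the two cores is not broken down here. In this assay compound 3 gives 47.2%, a number that stands between those of compound 1 and compound 2. Compound 4 `CNc1ncccc1C(=O)N/N=C/c1ccc(Cl)cc1` is not yet measured; it differs from compound 3 by chloro in place of hydrogen on an aromatic carbon. This is the same kind of change as that from compound 1 to compound 2, but not the same: in compound 2 the chloro sits meta to a large group, in compound 4 para to a large group, and the core is not the same. Going by the values given here, only one such step is known. For compound 4 in this assay a step of a number 14.8 percentage points higher from compound 3 to compound 4 (beyond the scatter) is expected, set smaller than a number 26.7 percentage points higher from compound 1 to compound 2 (beyond the scatter) for those two reasons. Compound 4 is estimated at 62%, between 46% and 78%.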

Compound 4, a percentage reported as inhibition, in the whole organism at one dose (the size of the read-out at that dose, not a potency): 54.1%
The estimate for compound 4 lay 7.9 percentage points above the measured number; measured number inside the range.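

In this assay, going by these compounds alone, chloro in place of hydrogen on the core of compound 3 gives a number 6.9 percentage points higher from compound 3 to compound 4 (within the scatter), so on this core the change brings no step that stands clear of the scatter. Within the data shown here, the gain seen on the core of compound 1, a number 26.7 percentage points higher from compound 1 to compound 2 (beyond the scatter), therefore does not carry over at the same size, and a step measured on one core is a poor guide to the step on the other: the same change on two cores in this assay, a number 26.7 percentage points higher (beyond the scatter) from compound 1 to compound 2 and a number 6.9 percentage points higher (within the scatter) from compound 3 to compound 4, 19.8 percentage points apart, beyond the scatter of two such steps This does not show that the core alone sets the size of the step, as the chloro in compound 4 sits para to a large group while that of compound 2 sits elsewhere on the ring, and each core offers only one such pair.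

Still open, from the compounds shown here alone, is how the same chloro placement behaves on both cores, which would separate the place of the chloro from the core. Also open, going by these compounds, is whether another group on that ring, such as methoxy, an amine or a carboxylic acid, behaves alike on the two cores.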